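The source may report more compounds than this note shows. Statements on the series, on what has been measured and on what is new or still open speak of the compounds shown alone.

Working notes on the series. In a functional assay for inhibition (on this read-out higher numbers stand for weaker inhibition and lower numbers for stronger inhibition), compound 1 `CC(C)(C)c1cc(-c2cc(=O)c3ccc(OCCO)cc3o2)cc(C(C)(C)C)c1O` gives 3000 nM and compound 2 `CC(C)(C)c1cc(-c2cc(=O)c3ccc(OCc4ccc(Cl)cc4)cc3o2)cc(C(C)(C)C)c1O` gives 7000 nM. Compound 3 `CC(C)(C)c1cc(-c2cc(=O)c3ccc(OCC(=O)O)cc3o2)cc(C(C)(C)C)c1O` gives 3000 nM; 100 nM (2 entries), so it offers no single number to compare with.

Compound 2 holds the higher of the two single numbers. Within the data shown here, the one measured step that reaches it reads a 2.3-fold higher number from compound 1 to compound 2 (0.37 log units; beyond the scatter), which is modest.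

The next structure is compound 4 `CC(C)(C)c1cc(-c2cc(=O)c3ccc(OCC(=O)N4CCCCC4)cc3o2)cc(C(C)(C)C)c1O`. The change is (piperidin-1-yl)carbonyl in place of 4-chlorophenyl on a saturated chain carbon bound to an oxygen on an aromatic ring. Cut one bond further out, the same difference reads (4-chlorobenzyl)oxy to ((piperidin-1-yl)carbonyl)methoxy.

Two pieces of evidence bear on this change. The first is the step into compound 2 at this same place, a 2.3-fold higher number from compound 1 to compound 2 (0.37 log units; beyond the scatter). The second is the spread in the several entries of compound 3 in this assay, 3000 nM; 100 nM (2 entries), which is too wide to anchor a prediction and mainly argues for a broad range. Replacing 4-chlorophenyl may therefore undo a change of about that modest size. The step expected in this assay is modest and towards a lower number: a 2.3-fold lower number from compound 2 to compound 4 (0.37 log units; beyond the scatter). For compound 4 the estimated value is 3000 nM, with an expected range from 700 nM to 10000 nM.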

Compound 4, half-maximal inhibitory concentration: 3000 nM
The estimate for compound 4 equals the measured number at the digits printed; low and high end bracket the measured number.
By their numbers in this assay, from the lowest: compounds 1 and 4 (each within the scatter of the next); then compound 2.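

Replacing 4-chlorophenyl with (piperidin-1-yl)carbonyl gives a 2.3-fold lower number from compound 2 to compound 4 (0.37 log units; beyond the scatter), so in this assay the higher number of compound 2 does not carry over to every ring-bearing group at this place. Set against the hydroxymethyl end, the same group gives no change at the digits printed from compound 1 to compound 4 (within the scatter), so this read-out does not separate these two ends, even though they differ in ring and in size of the group as counted in heavy atoms. Among the three compounds with a single number, only compound 2, with its 4-chlorophenyl, stands apart, and these few compounds do not show whether that holds for aryl groups in general or for this one group alone.

Still open, on these data alone, is how an open-chain amine on the carbonyl, a morpholine amide in place of the piperidine amide, or a longer chain between the oxygen and the carbonyl would read on this assay. The place of the carboxylic acid of compound 3 relative to compound 4 also stays unsettled, as its entries do not agree: the several entries of compound 3 in this assay, 3000 nM; 100 nM (2 entries)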